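A few compounds are considered here, and "the series" means these few. Any claim that something is new, unique, unknown or untested is made for them only; others in the source may bear on it.

Among the compounds with values here, in a functional assay on the whole organism for positive allosteric modulation, with Mus musculus as the target (a higher number here means that more compound is needed for the effect, a lower number that less compound is needed), compound 1 `CCC(=O)N(c1cccc(OC)c1)C1CCCC1N(C)C` gives 0.8 mg/kg, the lower of the two numbers measured so far. Compound 2 `CCC(=O)N(c1ccc(OC)c(OC)c1)C1CCCC1N(C)C`, with one more methoxy on an aromatic carbon, gives 9 mg/kg. That is an 11-fold higher number from compound 1 to compound 2 (1.05 log units; beyond the scatter), a large step and the only one measured. Compound 3 `CCC(=O)N(c1cccc(Cl)c1)C1CCCC1N(C)C` has not yet been measured. Its difference from compound 1 is chloro in place of methoxy on an aromatic carbon, meta to a large group. The measured step bears on this only indirectly, since it adds a methoxy rather than exchanging one. Within the data shown here, it shows that a change on this aromatic ring can move the number a long way in this assay, but no measured compound carries chloro, so the data give no direct guide to this exchange. A modest rise is therefore expected, with a wide margin on either side. The expected step is a 1.9-fold higher number from compound 1 to compound 3 (0.27 log units; within the scatter). The estimate for compound 3 is 1.5 mg/kg, with an expected range from 0.4 mg/kg to 6 mg/kg.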

Compound 3, dose for half-maximal effect: 0.4 mg/kg
The estimate for compound 3 lay 3.8-fold (0.57 log units) above the measured number, within the range that was stated.
By their numbers in this assay, from the lowest: compounds 3 and 1 (each within the scatter of the next); then compound 2.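

In this assay the exchange of methoxy for chloro gives a 2.0-fold lower number from compound 1 to compound 3 (0.30 log units; within the scatter) and so leaves compound 1 and compound 3 indistinguishable. Within the data shown here, the only earlier step on this ring, an 11-fold higher number from compound 1 to compound 2 (1.05 log units; beyond the scatter), came from adding a methoxy and showed how far a change on the ring can move the number, whereas this exchange shows that the methoxy meta to a large group can give way to a chloro, with one heavy atom in place of two and no hydrogen-bond acceptor in place of one, while the number stays within the scatter, so for this pair the oxygen of the methoxy is not needed to reach a number of this size. No measurement at hand accounts for this result.

From the compounds shown here alone, it remains open whether a plain hydrogen, a fluoro, a trifluoromethyl or an amine at this place would also stay within the scatter of compound 1. Among these compounds, it is also open whether a further methoxy on the ring of compound 3 would bring a step as large as the one seen with compound 2.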